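The source may hold more compounds than are shown below. What is called first, only, known or untested is meant among the compounds shown, and "the series" means these compounds.

Measured in a functional assay on FM3A cells (Mus musculus) for cytotoxicity; on this read-out lower numbers stand for an effect already at smaller amounts and higher numbers for an effect only at larger amounts of compound:
- compound 1 `COOC1(OOCCCCCCI)CCCCCCCCCCC1`: 86000 nM
- compound 2 `COOC1(OOC(C)(C)OC)CCCCCCCCCCC1`: 7300 nM
- compound 3 `CCOC(C)OOC1(OOC)CCCCCCCCCCC1`: 12000 nM

Compound 3 stands with compound 2 on these numbers, as a 1.6-fold higher number from compound 2 to compound 3 (0.22 log units; within the scatter) shows. Compound 1 stands apart from both, as shown by a 12-fold lower number from compound 1 to compound 2 (1.07 log units; beyond the scatter) and a 7.2-fold lower number from compound 1 to compound 3 (0.86 log units; beyond the scatter).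

The next compound is compound 4 `COOC1(OOCCCCCCO)CCCCCCCCCCC1`, with 6-hydroxyhexyl in place of 1-ethoxyethyl on an oxygen. The closest measured evidence is the pair of steps away from the 6-iodohexyl of compound 1. Going by the values given here, of these, a 7.2-fold lower number from compound 1 to compound 3 (0.86 log units; beyond the scatter) is the one that swaps the same 1-ethoxyethyl. The step between the two non-hexyl groups, a 1.6-fold higher number from compound 2 to compound 3 (0.22 log units; within the scatter), says little here, since neither group is the one entering.

Among the compounds with values here, the 6-hydroxyhexyl group itself has no measurement, and only three compounds support the comparison. Compound 4 keeps a hexyl chain, as compound 1 does, so a move towards the value of compound 1 is expected, though not necessarily all the way. In this assay the expected change is therefore a higher number, beyond the scatter but smaller than the step linking compound 1 and compound 3. The step expected is a 2.9-fold higher number from compound 3 to compound 4 (0.46 log units; beyond the scatter). For compound 4 the estimated value is 35000 nM, with an expected range of 11000 nM to 100000 nM.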

Compound 4, half-maximal effective concentration: 1600 nM
For compound 4 the middle estimate is 22-fold (1.34 log units) above the measured one; the measured number lies below the stated range.
By their numbers in this assay, from the lowest: compound 4; then compounds 2 and 3 (each within the scatter of the next); then compound 1.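

In this assay a hexyl chain on this oxygen does not by itself go with a high number: with hydroxy in place of iodo at the chain end, the step is a 54-fold lower number from compound 1 to compound 4 (1.73 log units; beyond the scatter), the largest in the series, so the end of the chain counts for more here than its presence. The 6-hydroxyhexyl group also goes past both shorter groups, with a 7.5-fold lower number from compound 3 to compound 4 (0.88 log units; beyond the scatter) against 1-ethoxyethyl and a 4.6-fold lower number from compound 2 to compound 4 (0.66 log units; beyond the scatter) against 1-methoxy-1-methylethyl, which gives it the lowest number of the four groups seen on this oxygen and removes any simple reading in which a hexyl chain raises the number. No measurement here bears on why the chain end shifts the number this far.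

Still open, going by these compounds, is whether the hydroxy group itself matters or any replacement for iodo would do, which a 6-aminohexyl chain, a carboxylic acid at the chain end or an unsubstituted hexyl chain would help to separate, and whether chain length matters, as a 4-hydroxybutyl or 8-hydroxyoctyl group would show. On these data alone, the group on the other oxygen is the same methyl in all four compounds, so whether these steps carry over to an ethyl group there also remains open.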